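Bromo for methyl: expected clearance of compound 4

The source may hold more compounds than are shown below. What is called first, only, known or untested is meant among the compounds shown, and "the series" means these compounds.

Compound 1 `O=C(c1cc(-n2ccc3ccccc32)c(O)cc1O)N1Cc2ccccc2C1`: 25 mL.min-1.g-1
Compound 2 `Cc1ccc2c(ccn2-c2cc(C(=O)N3Cc4ccccc4C3)c(O)cc2O)c1`: 42 mL.min-1.g-1
Compound 3 `O=C(c1cc(Nc2ccc(Cl)cc2Cl)c(O)cc1O)N1Cc2ccccc2C1`: 16 mL.min-1.g-1

These three numbers come from an ADME assay (liver) for metabolic stability, with Liver microsome (Rattus norvegicus) as the target, read by LC-MS, using microsomes, with a stated time of 5 min, tested at 1 uM; on this read-out lower numbers stand for slow clearance and higher numbers for fast clearance. Compound 2 stands at the upper end of them, level within the scatter with compound 1, while the gap down to compound 3 lies beyond the scatter.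

The unmeasured compound 4 `O=C(c1cc(-n2ccc3cc(Br)ccc32)c(O)cc1O)N1Cc2ccccc2C1` keeps the rest of compound 2 and differs in one group: bromo in place of methyl on an aromatic carbon. In words, this is bromo in place of methyl on an aromatic carbon, on a six-membered aromatic ring of carbon only that is part of a fused or bridged system of two rings.

The closest evidence is a 1.7-fold higher number from compound 1 to compound 2 (0.23 log units; within the scatter), where methyl replaces hydrogen on an aromatic carbon. The other measured step, a 1.6-fold lower number from compound 1 to compound 3 (0.19 log units; within the scatter), replaces the whole 1H-indol-1-yl group and bears on this change only loosely. Within the data shown here, no measured compound carries bromo, so neither step shows its effect directly. Since both steps stay within the scatter, no step beyond the scatter is expected in this assay. The estimated change is a 1.3-fold lower number from compound 2 to compound 4 (0.10 log units; within the scatter), which is expected to stay within the scatter. For compound 4 the expected value is 33 mL.min-1.g-1, with an estimated range from 17 mL.min-1.g-1 to 62 mL.min-1.g-1.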

Compound 4, intrinsic clearance in microsomes: 16 mL.min-1.g-1
Compound 4: the middle estimate sits 2.1-fold (0.31 log units) above what was measured, outside the stated range (below it).
By their numbers in this assay, from the lowest: compounds 3, 4, 1 and 2 (each within the scatter of the next, the first and the last beyond it).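

In this assay, among these compounds, the carbon on the six-membered aromatic ring that carries methyl in compound 2 proves sensitive to the choice of group: bromo in place of methyl gives a 2.6-fold lower number from compound 2 to compound 4 (0.42 log units; beyond the scatter) and is the only step at this position that lies beyond the scatter. Set against the unsubstituted compound 1, neither group stands clear on its own, since methyl gives a 1.7-fold higher number from compound 1 to compound 2 (0.23 log units; within the scatter) and bromo gives a 1.6-fold lower number from compound 1 to compound 4 (0.19 log units; within the scatter) in the opposite direction. Among the compounds shown here, the position therefore separates the two groups from each other in a way that the single methyl step could not show, although the data available offer no explanation for that separation.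

On these data alone, whether a chloro, methoxy or amino group on this carbon would fall with bromo, with methyl or outside both remains open, and a carboxylic acid or a longer chain such as propyl would test how far the number can move in either direction. As far as these compounds go, it is also open whether bromo on another carbon of the same six-membered ring would give a similar result in this assay or leave the number where compound 1 stands.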